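The source may hold more compounds than are shown below. What is called first, only, known or untested is meant among the compounds shown, and "the series" means these compounds.

Working notes on the series in an ADME assay on the whole organism (plasma) for pharmacokinetics, with Rattus norvegicus as the target, with a stated time of 24 h, at a dose of 10 mg/kg by the oral route; on this read-out lower numbers stand for lower exposure and higher numbers for higher exposure at the dose given: compound 1 (`Cc1ccc2c(c1)c(-c1ccc[nH]c1=O)c(C(=O)NS(=O)(=O)C(C)C)n2Cc1cc(F)ccc1F`) gives 3400 ng.h/mL, compound 2 (`CCc1ccc2c(c1)c(-c1ccc[nH]c1=O)c(C(=O)NS(C)(=O)=O)n2Cc1cc(F)ccc1F`) gives 35000 ng.h/mL, and compound 3 (`CCc1ccc2c(c1)c(-c1ccc[nH]c1=O)c(C(=O)NS(=O)(=O)CC)n2Cc1cc(F)ccc1F`) gives 2300 ng.h/mL. Compound 3 lies within the scatter of compound 1 and far under compound 2. Compound 4 (`CCc1ccc2c(c1)c(-c1ccc[nH]c1=O)c(C(=O)NS(=O)(=O)C(C)C)n2Cc1cc(F)ccc1F`) follows from compound 3 by methyl in place of hydrogen on a saturated chain carbon bound to a saturated chain carbon and a sulfonyl sulfur, read as ethylsulfonyl to isopropylsulfonyl. Among the measured compounds shown here, the one measured step of a similar kind, a 15-fold lower number from compound 2 to compound 3 (1.18 log units; beyond the scatter), was large, but it sits on a carbon with a different substitution. Compound 1, which carries isopropylsulfonyl on a slightly different core, gives 3400 ng.h/mL, so no further large fall is expected. The expected step, a 1.0-fold lower number from compound 3 to compound 4 (0.02 log units; within the scatter), stays within the scatter. Compound 4 is estimated at 2200 ng.h/mL, with an expected range of 700 ng.h/mL to 7000 ng.h/mL.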

Compound 4, area under the concentration-time curve: 411 ng.h/mL
Compound 4: the middle estimate sits 5.4-fold (0.73 log units) above what was measured, outside the stated range (below it).
By their numbers in this assay, from the lowest: compound 4; then compounds 3 and 1 (each within the scatter of the next); then compound 2.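

In this assay the fall does not stop at ethylsulfonyl: isopropylsulfonyl gives a 5.6-fold lower number from compound 3 to compound 4 (0.75 log units; beyond the scatter) and, counted from methylsulfonyl, isopropyl in place of methyl on a sulfonyl sulfur gives an 85-fold lower number from compound 2 to compound 4 (1.93 log units; beyond the scatter) in a single change. Methyl in place of hydrogen on a saturated chain carbon bound to an aromatic carbon also lowers exposure, with an 8.3-fold lower number from compound 1 to compound 4 (0.92 log units; beyond the scatter) among the isopropylsulfonyl compounds, so the sensitivity is not confined to the sulfonyl side. That step and the step from methylsulfonyl to ethylsulfonyl are close in size: the same change on two cores in this assay, a 15-fold lower number (1.18 log units; beyond the scatter) from compound 2 to compound 3 and an 8.3-fold lower number (0.92 log units; beyond the scatter) from compound 1 to compound 4, 1.8-fold (0.26 log units) apart, within the scatter of two such steps. Open, going by these compounds, is whether an amine or a longer chain on the sulfonyl sulfur continues the fall, and whether methylsulfonyl holds its high exposure with methyl in place of ethyl on the core.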